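Swapping the Phenyl Group of Compound 3

A few compounds are considered here, and "the series" means these few. Any claim that something is new, unique, unknown or untested is made for them only; others in the source may bear on it.

Three compounds share one core and differ only in the phenyl group they carry: compound 1 (`Cc1oc(-c2c(F)cccc2F)nc1CN1CCC(C(=O)NCCCN2C[C@H](C)C[C@H](C)C2)CC1`), compound 2 (`Cc1oc(-c2c(Cl)cccc2C(F)(F)F)nc1CN1CCC(C(=O)NCCCN2C[C@H](C)C[C@H](C)C2)CC1`) and compound 3 (`COc1cccc(C)c1-c1nc(CN2CCC(C(=O)NCCCN3C[C@H](C)C[C@H](C)C3)CC2)c(C)o1`). In a physicochemical assay for solubility, in phosphate buffer, measured as kinetic solubility, at pH 7.4 (on this read-out lower numbers stand for lower solubility and higher numbers for higher solubility), compound 3 gives > 73 ug/mL, which is a limit of the assay and not a number. Compound 1 gives > 72 ug/mL, again a limit and not a number. Compound 2 is the only one of the three with a true number, 65.1 ug/mL. The measured steps are an at least 1.1-fold lower number from compound 1 to compound 2 (0.04 log units; that floor lies within the scatter), an at least 1.1-fold higher number from compound 2 to compound 3 (0.04 log units; that floor lies within the scatter) and a step that the two limits leave unreadable from compound 1 to compound 3. All three exchange one phenyl group for another at the same place.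

Compound 4 (`Cc1cc(C)cc(-c2nc(CN3CCC(C(=O)NCCCN4C[C@H](C)C[C@H](C)C4)CC3)c(C)o2)c1`) has 3,5-dimethylphenyl in place of the 2-methoxy-6-methylphenyl of compound 3, on an aromatic carbon: 3,5-dimethylphenyl in place of 2-methoxy-6-methylphenyl on an aromatic carbon. Judging from an at least 1.1-fold higher number from compound 2 to compound 3 (0.04 log units; that floor lies within the scatter), this exchange is expected to show no step beyond the scatter in this assay. The estimated change is an at least 1.2-fold lower number from compound 3 to compound 4 (0.08 log units; that floor lies within the scatter). For compound 4 the estimate is 60 ug/mL, with the result expected between 28 ug/mL and 80 ug/mL.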

Compound 4, solubility: > 71 ug/mL
Compound 4: a limit, no number; the forecaster's own chance of this, stated with the estimate: 40%; middle value at least 1.1-fold (0.07 log units) away from the limit.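

Replacing 2-methoxy-6-methylphenyl with 3,5-dimethylphenyl, which has no hydrogen-bond acceptor, still leaves compound 4 as a limit rather than a number in this assay, as compound 1 and compound 3 are. Among the compounds shown here, the only readable comparison gives an at least 1.0-fold higher number from compound 2 to compound 4 (0.03 log units; that floor lies within the scatter), so this position shows no separation beyond the scatter from compound 2, even with this different phenyl group. The steps from compound 3 and from compound 1 to compound 4 cannot be read because both ends of each are limits: the limit of > 71 ug/mL in this assay, at which 1 of the 4 values shown sits.

True numbers for compound 1, compound 3 and compound 4 remain open, so any order among them is unknown. Also open, from the compounds shown here alone, is what an amine or a carboxylic acid on the phenyl group would do at this position.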